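Aryl variation on the shared core, before compound 3

The source may report more compounds than this note shows. Statements on the series, on what has been measured and on what is new or still open speak of the compounds shown alone.

Compound 1 `COc1cc(-c2nccn3cc(-c4ccc5[nH]ccc5c4)nc23)cc(OC)c1OC` carries 1H-indol-5-yl on the shared core. In a functional assay on MDA-MB-231 cells (Homo sapiens) for inhibition, read by MTT assay, with a stated time of 48 h (a lower number here means a stronger inhibitor, a higher number a weaker inhibitor), compound 1 gives 74 nM; of the two numbers in hand it is the lowest, the other belonging to compound 2 `COc1cc(-c2nccn3cc(-c4ccccc4)nc23)cc(OC)c1OC`, which in this assay gives 364 nM. Within the data shown here, the single measured step, a 4.9-fold higher number from compound 1 to compound 2 (0.69 log units; beyond the scatter), is the only guide to how the aryl group on that aromatic carbon sets the number.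

Compound 3 `COc1cc(-c2nccn3cc(-c4ccc(C(F)(F)F)cc4)nc23)cc(OC)c1OC` is not yet measured. Its change from compound 1: 4-(trifluoromethyl)phenyl in place of 1H-indol-5-yl on an aromatic carbon. Among the measured compounds shown here, the step from compound 1 to compound 2 bears on it directly, since both changes take away 1H-indol-5-yl and bring in a six-membered aromatic ring of carbon only; no measured step tells what the trifluoromethyl group on that ring adds, so that part is unknown. Because a 4.9-fold higher number from compound 1 to compound 2 (0.69 log units; beyond the scatter) was modest yet beyond the scatter, a step of about that size in the same direction is expected for compound 3, rather than none. Compound 3 is therefore estimated at 400 nM in this assay, within 150 nM to 1200 nM. That estimate means an expected step of a 5.4-fold higher number from compound 1 to compound 3 (0.73 log units; beyond the scatter).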

Compound 3, half-maximal inhibitory concentration: > 10000 nM
Compound 3: a limit, no number; the forecaster's own chance of this, stated with the estimate: 3%; at least 25-fold (1.39 log units) between middle value and limit.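

In this assay compound 3 stands at a limit of the assay and not at a number, so the steps to it have a floor but no definite size: the limit of > 10000 nM in this assay, at which 1 of the 3 values shown sits.

Adding trifluoromethyl in place of hydrogen on the phenyl ring gives an at least 27-fold higher number from compound 2 to compound 3 (1.43 log units; beyond the scatter), which shows that the number at this aromatic carbon of the five-membered aromatic ring with 2 nitrogen depends on what the six-membered ring carries, and not only on the loss of 1H-indol-5-yl. With the replacement of 1H-indol-5-yl by 4-(trifluoromethyl)phenyl giving an at least 130-fold higher number from compound 1 to compound 3 (2.13 log units; beyond the scatter), a large step, while the replacement by phenyl gives the modest 4.9-fold higher number from compound 1 to compound 2 (0.69 log units; beyond the scatter), carbon-only six-membered aromatic rings at this position do not behave as one class.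

The compounds shown do not tell whether the large step belongs to trifluoromethyl alone or would also follow from fluorine, methoxy, an amine or a carboxylic acid on the same ring. On these data alone, they also leave open whether the hydrogen-bond donor of 1H-indol-5-yl or its five-membered ring sets the lower number of compound 1, a question that a benzofuran-5-yl group at this place would address, and the reason for the limit of compound 3 remains unknown.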